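A few compounds are considered here, and "the series" means these few. Any claim that something is new, unique, unknown or untested is made for them only; others in the source may bear on it.

Within the data shown here, in a functional assay on NCI-H460 cells (Homo sapiens) for antiproliferative activity, read by MTT assay, with a stated time of 48 h (a higher number here means a weaker inhibitor, a lower number a stronger inhibitor), three compounds have numbers so far. Compound 1 `CC(C)C/C=C1/C(=O)Nc2ccc(Nc3ccc(Cl)cc3)cc21` gives 50900 nM and compound 2 `Cc1ccc(Nc2ccc3c(c2)C(CCC(C)C)C(=O)N3)cc1` gives 55300 nM so these two sit within the usual scatter of each other. Compound 3 `CCCCCC1(O)C(=O)Nc2ccc(Nc3ccc(OC)cc3)cc21` gives 16200 nM as the lowest number of the three, and its gap to each of the other two lies beyond the scatter. That makes it the strongest inhibitor of this small set. Among the measured compounds shown here, the three compounds differ from one another in more than one place, so no measured pair shows what a single change does.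

Compound 4 `CCCCCCC1(O)C(=O)Nc2ccc(Nc3ccc(OC)cc3)cc21` differs from compound 3 in one place only. The change is methyl in place of hydrogen on a saturated chain carbon, five bonds along the chain from a saturated ring carbon and it amounts to methyl in place of hydrogen on a saturated chain carbon, five bonds along the chain from a saturated ring carbon. For the measured compounds named here, no measured step of this kind exists to lean on, so the expectation starts from compound 3 at 16200 nM and assumes only a small move. The expected move is a 1.2-fold lower number from compound 3 to compound 4 (0.06 log units; within the scatter) toward a slightly lower number, and it would not go beyond the scatter. For compound 4 the estimate is 14000 nM with a range from 6000 nM to 32000 nM expected for the measurement.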

Compound 4, half-maximal inhibitory concentration: > 100000 nM
Compound 4: a limit, no number; the forecaster's own chance of this, stated with the estimate: 5%; middle value at least 7.1-fold (0.85 log units) away from the limit.
By their numbers in this assay, from the lowest: compound 3; then compounds 1 and 2 (each within the scatter of the next). At a limit, above all of these: compound 4.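

In this assay, among these compounds, placing methyl in place of hydrogen on a saturated chain carbon, five bonds along the chain from a saturated ring carbon, gives an at least 6.1-fold higher number from compound 3 to compound 4 (0.79 log units; beyond the scatter), and this is the first step in the set that isolates a single change. Compound 4 gives > 100000 nM, which is a limit of the assay and not a number. Compounds 1, 2 and 3 differ from one another in more than one place and could not show what this position tolerates, whereas this pair shows that adding a single carbon here, with no ring, no hydrogen-bond donor or acceptor and no charge, is enough to lose measurable activity in this assay at the concentrations reported.

Going by these compounds, how large the loss truly is stays open, since only its lower bound can be read: the limit of > 100000 nM in this assay, at which 1 of the 4 values shown sits. Also open, on these data alone, is what a longer chain, or an amine or a carboxylic acid in place of the methyl at this carbon, would do to the number, and whether the same step would have the same effect on another core.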